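Chlorine position on the benzylsulfanyl arm

The source may report more compounds than this note shows. Statements on the series, on what has been measured and on what is new or still open speak of the compounds shown alone.

Two members of the series have numbers. In a functional assay on the whole organism (artery, strain albino) with Rattus norvegicus as the target, with a stated time of 300 min, at a dose of 10 mg/kg by the oral route (a higher number here means more inhibition at the dose given (going by the name of the read-out), a lower number less inhibition), compound 1 `COc1ccc(C2N=C(SCc3ccccc3Cl)NC(C)=C2C(=O)Nc2ccc(F)cc2)cc1OC` gives 35.9% and compound 2 `CC1=C(C(=O)Nc2ccc(F)cc2)C(c2ccc([N+](=O)[O-])cc2)N=C(SCc2ccccc2Cl)N1` gives 18.5%. Among the measured compounds shown here, the single measured step, a number 17.4 percentage points lower from compound 1 to compound 2 (beyond the scatter), concerns the aryl group on the saturated ring carbon. Compound 2 therefore stands lowest of the two measured compounds, with compound 1 the nearest neighbour and beyond the scatter above it.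

Compound 3 `CC1=C(C(=O)Nc2ccc(F)cc2)C(c2ccc([N+](=O)[O-])cc2)N=C(SCc2ccc(Cl)cc2)N1` keeps the whole core of compound 2 and differs only in 4-chlorophenyl in place of 2-chlorophenyl on a saturated chain carbon bound to a sulfur. For the measured compounds named here, no measured step touches this arm of the molecule; the one available step, a number 17.4 percentage points lower from compound 1 to compound 2 (beyond the scatter), moves a different group and says nothing about where the chlorine sits on the benzyl ring. With nothing to point in either direction, no step beyond the scatter is expected, so no change at the digits printed from compound 2 to compound 3 (within the scatter) is the estimated outcome. Compound 3 is expected to give 18.5% in this assay, within 5% to 35%.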

Compound 3, a percentage reported as inhibition, in the whole organism at one dose (the size of the read-out at that dose, not a potency): 37.9%
Estimate against measurement, compound 3: 19.4 percentage points below; the measured number lies above the stated range.
By their numbers in this assay, from the lowest: compound 2; then compounds 1 and 3 (each within the scatter of the next).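

The arm on the sulfur responds to a change that alters neither its atoms nor its counted features: in this assay, 2-chlorobenzyl to 4-chlorobenzyl gives a number 19.4 percentage points higher from compound 2 to compound 3 (beyond the scatter). The aryl group on the saturated ring carbon is therefore no longer the only place in the series where a step beyond the scatter is seen, and the placing of the chlorine on the benzyl ring counts in its own right. Nothing available bears on why the 4-chlorobenzyl compound reads differently from its 2-chlorobenzyl partner.

On these data alone, whether this step carries over to compounds with 3,4-dimethoxyphenyl on the saturated ring carbon remains open. A plain benzyl or a 4-methoxybenzyl on the sulfur would show whether the chlorine itself is needed or whether other groups can fill that place.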